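Hydrazone aryl replacements on a shared core: working notes

A few compounds are considered here, and "the series" means these few. Any claim that something is new, unique, unknown or untested is made for them only; others in the source may bear on it.

Measured so far:
compound 1 `O=C(CSc1nnc(-c2ccncc2)o1)N/N=C/c1ccc(O)cc1` — 12200 nM
compound 2 `O=C(CSc1nnc(-c2ccncc2)o1)N/N=C/c1cccc(F)c1` — 26700 nM

Both numbers come from a functional assay on SW 1116 cells (Homo sapiens) for cytotoxicity, read by MTT assay, with a stated time of 48 h; a lower number here means a stronger inhibitor, a higher number a weaker inhibitor. Among the compounds with values here, of the two, compound 1 stands lowest; its nearest neighbour is compound 2, and the single measured step between them is a 2.2-fold higher number from compound 1 to compound 2 (0.34 log units; beyond the scatter), in which 3-fluorophenyl replaces 4-hydroxyphenyl on a carbon with a double bond to nitrogen.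

Compound 3 `O=C(CSc1nnc(-c2ccncc2)o1)N/N=C/C=C/c1ccccc1` has not been measured in this assay. Against compound 1 the change is 2-phenylethenyl in place of 4-hydroxyphenyl on a carbon with a double bond to nitrogen.

The step from compound 1 to compound 2 is the only one that bears on this: it also removes 4-hydroxyphenyl from the same carbon, and it cost a modest amount of potency, beyond the scatter. Compound 3 goes one step further in that it brings in a group without any hydrogen-bond donor or acceptor, so a weakening of similar or somewhat larger size is expected, though the data hold nothing on 2-phenylethenyl itself and the range must stay wide.

For compound 3 the expected value in this assay is 22000 nM, with a range of 8000 nM to 60000 nM. This estimate corresponds to a step of a 1.8-fold higher number from compound 1 to compound 3 (0.26 log units; within the scatter).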

Compound 3, half-maximal inhibitory concentration: 14900 nM
The estimate for compound 3 lay 1.5-fold (0.17 log units) above the measured number; the measured number falls inside the stated range.
By their numbers in this assay, from the lowest: compounds 1, 3 and 2 (each within the scatter of the next, the first and the last beyond it).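

In this assay, within the data shown here, the step to 2-phenylethenyl on a carbon with a double bond to nitrogen is a 1.2-fold higher number from compound 1 to compound 3 (0.09 log units; within the scatter), so this replacement cannot be told apart from 4-hydroxyphenyl, even though the 1 hydrogen-bond donor and 1 hydrogen-bond acceptor counted in the group that leaves have no counterpart in the group that enters. The same compound also cannot be told apart from the 3-fluorophenyl analogue, with a 1.8-fold lower number from compound 2 to compound 3 (0.25 log units; within the scatter), which leaves compound 3 unplaced within the only gap beyond the scatter so far, a 2.2-fold higher number from compound 1 to compound 2 (0.34 log units; beyond the scatter). The three compounds therefore show that this place accepts a group other than a directly attached substituted phenyl ring without a step beyond the scatter from either neighbour, and no measurement on hand accounts for how these groups read.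

Still open, on these data alone, is whether 2-phenylethyl, which lacks the double bond outside aromatic rings, reads like 2-phenylethenyl at this place. Also open, as far as these compounds go, is whether an amine or a carboxylic acid in place of the hydroxyl of 4-hydroxyphenyl would stay within the scatter of compound 1.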